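Carboxy in Place of Chloro: What to Expect for Compound 4

A few compounds are considered here, and "the series" means these few. Any claim that something is new, unique, unknown or untested is made for them only; others in the source may bear on it.

Three compounds sharing one core have been tested in a toxicity assay on MCF-10A cells (Homo sapiens) for cytotoxicity, read by MTT assay, with a stated time of 48 h; a higher number here means a weaker inhibitor, a lower number a stronger inhibitor:

compound 1, `O=C(/C=C/c1ccc2c(c1)B(O)OC2)c1cccnc1`: 34400 nM
compound 2, `O=C(/C=C/c1ccc2c(c1)B(O)OC2)c1ccc(Cl)cc1`: 12100 nM
compound 3, `Nc1cccc(C(=O)/C=C/c2ccc3c(c2)B(O)OC3)c1`: 19600 nM

Compound 2 shows the lowest number of the three in this assay. Its nearest neighbour is compound 3, a 1.6-fold higher number from compound 2 to compound 3 (0.21 log units; within the scatter), a gap inside the scatter, so the two cannot be ordered. The gap to compound 1 is larger: a 2.8-fold lower number from compound 1 to compound 2 (0.45 log units; beyond the scatter), which lies beyond the scatter and is the only clear difference among the three.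

Compound 4, `O=C(O)c1ccc(C(=O)/C=C/c2ccc3c(c2)B(O)OC3)cc1`, has not yet been measured in this assay. It differs from compound 2 in this way: carboxy in place of chloro on an aromatic carbon The chloro leaves and a carboxy enters on an aromatic carbon of a six-membered aromatic ring of carbon only.

Among the measured compounds shown here, the steps that bear on this are the two that also exchange the group on the carbonyl carbon, a 2.8-fold lower number from compound 1 to compound 2 (0.45 log units; beyond the scatter) and a 1.6-fold higher number from compound 2 to compound 3 (0.21 log units; within the scatter). Both are modest, and neither exchange resembles a carboxy entering. Since all three measured changes at this position stayed modest, a modest step is expected for compound 4 too, most likely toward a higher number in this assay, as the two neighbours of compound 2 both sit higher. Compound 4 is therefore estimated at 22000 nM, within a range of 9000 nM to 60000 nM, which corresponds to an expected step of a 1.8-fold higher number from compound 2 to compound 4 (0.26 log units; within the scatter).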

Compound 4, half-maximal inhibitory concentration: > 100000 nM
Compound 4: a limit, no number; the forecaster's own chance of this, stated with the estimate: 15%; middle value at least 4.5-fold (0.65 log units) from the limit.
By their numbers in this assay, from the lowest: compounds 2, 3 and 1 (each within the scatter of the next, the first and the last beyond it). At a limit, above all of these: compound 4.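

In this assay, compound 4 gives > 100000 nM, which is a limit of the assay and not a number. Putting a carboxy in place of chloro on an aromatic carbon, para to a large group, gives an at least 8.2-fold higher number from compound 2 to compound 4 (0.91 log units; beyond the scatter), so this step lies beyond the scatter and its full size cannot be read. The earlier compounds, which carried pyridin-3-yl, 4-chlorophenyl or 3-aminophenyl on the carbonyl carbon, had given only modest steps and no sign that a single exchange on this ring could carry the number up to the top of the readable range, and compound 4 is the only compound that reaches it: the limit of > 100000 nM in this assay, at which 1 of the 4 values shown sits.

The compounds shown leave open whether this shift belongs to the free carboxylic acid itself or would also appear with a methyl ester or a primary amide at the same place. They also give no cause for the shift, and they do not tell how far the true value of compound 4 lies beyond its limit.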